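A few compounds are considered here, and "the series" means these few. Any claim that something is new, unique, unknown or untested is made for them only; others in the source may bear on it.

Measured in a functional assay on the whole organism for antagonist activity, with Mus musculus as the target; a higher number here means that more compound is needed for the effect, a lower number that less compound is needed:
- compound 1 `CC(=O)N(C)C(C)C#CCn1ccnc1C`: 0.2 mg/kg
- compound 2 `CC(C#CCn1ccnc1)N1CCCC1=O`: 3.7 mg/kg
- compound 3 `Cc1cncn1CC#CC(C)N1CCCC1=O`: 2.5 mg/kg

Compound 2, at 3.7 mg/kg, sits with compound 3 at the high end of these numbers, and the two cannot be told apart: a 1.5-fold lower number from compound 2 to compound 3 (0.17 log units; within the scatter). Compound 1, at 0.2 mg/kg, stands clearly lower than both.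

The next compound to be measured is compound 4 `CC(C#CCN(C)C)N1CCCC1=O`. It is reached from compound 2 by dimethylamino in place of 1H-imidazol-1-yl on a saturated chain carbon bound to a triple-bonded carbon.

Within the data shown here, no measured step covers such a replacement. The only one, a 1.5-fold lower number from compound 2 to compound 3 (0.17 log units; within the scatter), is a methyl in place of hydrogen on an aromatic carbon, and it gives little guidance on size. All three measured compounds keep the aromatic ring that compound 4 lacks, so a modest move toward a higher number is expected, with wide uncertainty.

The expected change is a 2.2-fold higher number from compound 2 to compound 4 (0.33 log units; beyond the scatter). For compound 4 the estimated value is 8 mg/kg, with an expected range of 1.5 mg/kg to 50 mg/kg.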

Compound 4, dose for half-maximal effect: > 100 mg/kg
Compound 4: no number, only a limit; the forecaster's own chance of this, stated with the estimate: 25%; middle value at least 12-fold (1.09 log units) from the limit.
By their numbers in this assay, from the lowest: compound 1; then compounds 3 and 2 (each within the scatter of the next). At a limit, above all of these: compound 4.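

In this assay compound 4 gives only a limit, not a number: the limit of > 100 mg/kg in this assay, at which 1 of the 4 values shown sits.

At this place, on a saturated chain carbon bound to a triple-bonded carbon, exchanging 1H-imidazol-1-yl for dimethylamino gives a large change, an at least 27-fold higher number from compound 2 to compound 4 (1.43 log units; beyond the scatter). Among these compounds, the only earlier step, a 1.5-fold lower number from compound 2 to compound 3 (0.17 log units; within the scatter), altered the aromatic ring but kept it, so it could not show how much hangs on the group as a whole. Here the five-membered aromatic ring is lost altogether, and the change is far beyond the scatter.

The compounds shown leave open whether the aromatic ring itself counts or whether dimethylamino is a poor replacement in particular, a question that a phenyl group or a diethylamino group at this place would help to settle. As far as these compounds go, because compound 4 stands at a limit, the full size of this step also remains unknown.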